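Swapping one furan for a chlorinated one on a shared core

The source may hold more compounds than are shown below. What is called first, only, known or untested is meant among the compounds shown, and "the series" means these compounds.

In a functional assay on DU-145 cells (Homo sapiens) for cytotoxicity, in the presence of a further agent that is not named here (on this read-out higher numbers stand for weaker inhibition and lower numbers for stronger inhibition), compound 3 `Clc1ccc(-c2cc(-c3ccoc3)cc(-c3cccs3)n2)cc1` gives 21100 nM, the highest of the three numbers recorded, though within the usual scatter of both neighbours. Compound 2 `Clc1ccc(-c2cc(-c3ccc(Cl)o3)cc(-c3ccsc3)n2)cc1` gives 19500 nM and compound 1 `Clc1ccc(-c2cc(-c3cccnc3)nc(-c3cccs3)c2)o1` gives 13000 nM in this assay. Compound 4 `Clc1ccc(-c2cc(-c3ccc(Cl)o3)cc(-c3cccs3)n2)cc1` is not yet measured. It differs from compound 3 by a single change: 5-chlorofuran-2-yl in place of furan-3-yl on an aromatic carbon. Compound 2 already carries a 5-chlorofuran-2-yl group and its value sits close to that of compound 3, so no shift beyond the scatter is expected. The estimated step from compound 3 to compound 4 is a 1.1-fold lower number from compound 3 to compound 4 (0.05 log units; within the scatter). Compound 4 is expected to give about 19000 nM in this assay, likely between 9000 nM and 40000 nM.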

Compound 4, half-maximal inhibitory concentration: 19200 nM
Estimate against measurement, compound 4: 1.0-fold (0.00 log units) below; the measured number falls inside the stated range.
By their numbers in this assay, from the lowest: compounds 1, 4, 2 and 3 (each within the scatter of the next).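

In this assay the step for 5-chlorofuran-2-yl in place of furan-3-yl is a 1.1-fold lower number from compound 3 to compound 4 (0.04 log units; within the scatter) and so this swap, opposite the ring nitrogen, does not move the number beyond the scatter. The other two single changes read the same way, with thiophen-2-yl in place of thiophen-3-yl giving a 1.0-fold lower number from compound 2 to compound 4 (0.01 log units; within the scatter) and 4-chlorophenyl in place of pyridin-3-yl giving a 1.5-fold higher number from compound 1 to compound 4 (0.17 log units; within the scatter) on the shared core. Nothing available explains these results.

Still open, going by these compounds, is whether an amine or a carboxylic acid at this position would give a step beyond the scatter.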